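The source may hold more compounds than are shown below. What is called first, only, known or untested is meant among the compounds shown, and "the series" means these compounds.

Compound 1 `COc1cc(Cl)cc(-c2nn(-c3cccc(NC(=O)Nc4ccc(Cl)c(C(F)(F)F)c4)c3)cc2-c2ccncc2)c1`, compound 2 `COc1cc(Cl)cc(-c2nn(-c3cccc(NC(=O)Nc4ccc(Cl)c(Cl)c4)c3)cc2-c2ccncc2)c1` and compound 3 `COc1cc(Cl)cc(-c2nn(-c3cccc(NC(=O)Nc4cccc(C(F)(F)F)c4)c3)cc2-c2ccncc2)c1` share one core and differ only in the aromatic group carried on an amide-type nitrogen. In a functional assay on Hs-578T cells (Homo sapiens) for inhibition, read by sulforhodamine B assay, with a stated time of 48 h, tested at 0.01 uM (on this read-out lower numbers stand for a stronger effect and higher numbers for a weaker effect at the one concentration tested), compound 1 gives 95%, compound 2 gives 93% and compound 3 gives 99%. The three numbers lie close together: the steps are a number 2 percentage points lower from compound 1 to compound 2 (within the scatter), a number 4 percentage points higher from compound 1 to compound 3 (within the scatter) and a number 6 percentage points higher from compound 2 to compound 3 (within the scatter). Compound 3 thus stands at the top of the three numbers, yet its distances to compound 1 and to compound 2 both fall within the scatter, so no real ordering can be read from them. Compound 4 `COc1cc(Cl)cc(-c2nn(-c3cccc(NC(=O)c4cccc(C(F)(F)F)c4)c3)cc2-c2ccncc2)c1` brings a different kind of change: 3-(trifluoromethyl)phenyl in place of (3-(trifluoromethyl)phenyl)amino on a carbonyl carbon. Among the compounds with values here, none of the measured steps touches this part of the molecule; each only exchanges one group on an aromatic carbon or swaps the whole aromatic group on the amide-type nitrogen, so none bears directly on it. Since all three numbers sit in one narrow band, the expected step for compound 4 is a number 2 percentage points lower from compound 3 to compound 4 (within the scatter), within the scatter. The estimated value for compound 4 in this assay is 97%, with a range from 88% to 105%.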

Compound 4, a percentage reported as activity, at one concentration (the size of the read-out at that concentration, not a potency): 97%
Compound 4: middle estimate and measured number agree at the digits printed, and the stated range covers the measured number.
By their numbers in this assay, from the lowest: compounds 2, 1, 4 and 3 (each within the scatter of the next).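

Unlike the earlier steps, this change reaches the link itself: the group that leaves carries a nitrogen with one hydrogen-bond donor, the group that enters carries none, and in this assay the step stays small (a number 2 percentage points lower from compound 3 to compound 4 (within the scatter)). The comparisons with the other two ureas read the same way (a number 4 percentage points higher from compound 2 to compound 4 (within the scatter); a number 2 percentage points higher from compound 1 to compound 4 (within the scatter)), though these also change the aromatic group, so at this one low concentration, the loss of the nitrogen leaves the number inside the scatter. No measurement shown offers an explanation for this result.

Going by these compounds, all four numbers sit in one narrow band at a single concentration, so whether the link matters at higher concentrations stays open. Also open, on these data alone, is what a methylene group between the carbonyl carbon and the aromatic ring, or a sulfonyl group in place of the carbonyl, would do.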